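The compounds below may be only part of what the source reports. "The series", "measured", "known", "first", "only" and "open" are said of these compounds alone.

Measured in a functional assay on CUTLL1 cells (Homo sapiens) for inhibition, read by resazurin assay, with a stated time of 48 h, in the presence of a further agent that is not named here; on this read-out higher numbers stand for an effect only at larger amounts of compound and lower numbers for an effect already at smaller amounts:

Compound 1 (`Nc1ncc(-c2cccnc2)c(C2CC2)n1`) gives > 100000 nM, a limit.
Compound 2 (`Nc1ncc(-c2ccnc3ccccc23)c(C2CC2)n1`) gives > 100000 nM, a limit.
Compound 3 (`Cc1nc(N)ncc1-c1ccncc1`) gives > 100000 nM, a limit.

Compound 3 therefore has no exact number of its own. It shares its place with the other two compounds, and the whole picture so far is the limit of > 100000 nM in this assay, at which 3 of the 3 values shown sit. None of the three can be ranked against another.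

Compound 4 (`Nc1ncc(-c2ccncc2)c(-c2ccccc2)n1`) has phenyl in place of methyl on an aromatic carbon of compound 3, a change counted as phenyl in place of methyl on an aromatic carbon. Within the data shown here, no measured pair shows what a change at this place does, so the data offer no direct guide to its size. A small step towards lower numbers is the most that is expected, and another reading at the limit is the likeliest result. This expectation rests on compound 3, whose reading is the limit > 100000 nM. The expected change is an at least 1.1-fold lower number from compound 3 to compound 4 (0.04 log units; that floor lies within the scatter), judged against a limit and not an exact number. Compound 4 is estimated at 90000 nM, with an expected range from 30000 nM to 200000 nM.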

Compound 4, half-maximal effective concentration: > 100000 nM
Compound 4 ended at the assay's limit (the forecaster's own chance of this, stated with the estimate: 70%); middle value at least 1.1-fold (0.04 log units) from the limit.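

Compound 3 and compound 4 both read at a limit, so no step can be read for phenyl in place of methyl on an aromatic carbon. The compounds shown leave open whether any change to them would lower the number in this assay, as every reading rests at one limit: the limit of > 100000 nM in this assay, at which 4 of the 4 values shown sit.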